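The compounds below may be only part of what the source reports. "The series", "measured", "known", "first", "only" and "open" are said of these compounds alone.

Measured in a functional assay on KB cells (Homo sapiens) for inhibition; a lower number here means a stronger inhibitor, a higher number a weaker inhibitor:

Compound 1 `CC(=O)OC1C(CF)OC(n2c(Cl)nc3cc(Cl)c(Cl)cc32)C1OC(C)=O`: 100000 nM
Compound 2 `CCOC[C@H]1OC(n2c(Cl)nc3cc(Cl)c(Cl)cc32)[C@H](O)[C@@H]1O`: 80000 nM

With only these two numbers available, compound 2 at 80000 nM cannot be told apart from compound 1 at 100000 nM, since the two values lie within the usual scatter of repeated measurements.

The next compound to consider is compound 3 `O[C@@H]1[C@@H](CBr)OC(n2c(Cl)nc3cc(Cl)c(Cl)cc32)[C@@H]1O`, which has not yet been measured. Compared with compound 2, it carries one structural change: bromo in place of ethoxy on a saturated chain carbon bound to a saturated ring carbon. In plain words, bromo takes the place of ethoxy on a saturated chain carbon bound to a saturated ring carbon. Cut one bond further out, the same change reads ethoxymethyl to bromomethyl.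

Within the data shown here, no two measured compounds differ in just one place, so the data offer no direct guide to the size of this step. Without such a guide, no step beyond the scatter is expected in this assay. The expected change, a 1.6-fold lower number from compound 2 to compound 3 (0.20 log units; within the scatter), is therefore a cautious estimate. For compound 3 the estimated value is 50000 nM, with an expected range from 15000 nM to 150000 nM.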

Compound 3, half-maximal inhibitory concentration: 90000 nM
Compound 3: middle estimate off by 1.8-fold (0.26 log units), on the low side; the range from low to high includes it.
By their numbers in this assay, from the lowest: compounds 2, 3 and 1 (each within the scatter of the next).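

In this assay, among these compounds, the single change from ethoxy to bromo on a saturated chain carbon bound to a saturated ring carbon gives a 1.1-fold higher number from compound 2 to compound 3 (0.05 log units; within the scatter), so the two compounds cannot be told apart. Among the compounds shown here, this is the first comparison here of compounds that differ in only one place, and it shows that ethoxymethyl and bromomethyl give matching readings on this shared core, even though ethoxy brings a hydrogen-bond acceptor and bromo brings none. No measurement available here explains this result or bears on what lies behind it.

On these data alone, a single step between two groups says little about this position as a whole, so it remains open whether an amine, a carboxylic acid or a longer chain such as butoxy at the same place would give a number clearly apart from compound 2 at 80000 nM and compound 3 at 90000 nM. As far as these compounds go, it also remains open whether a free hydroxymethyl group there would read any differently from ethoxymethyl and bromomethyl.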